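From a two-ring aryl to a tert-butylphenyl

The compounds below may be only part of what the source reports. "The series", "measured", "known", "first", "only" and "open" are said of these compounds alone.

Compound 2 `COC(C(=O)OC(C)Cn1cnc2c1c(=O)n(C)c(=O)n2C)c1ccc2ccccc2c1` was tested in a functional assay on MCF7 cells (Homo sapiens) for antiproliferative activity, read by MTT assay, with a stated time of 72 h, tested at 50 uM (on this read-out higher numbers stand for a weaker effect at the one concentration tested and lower numbers for a stronger effect), where compound 2 gives 86.3%, the second highest of three numbers. Nearest is compound 1 `COC(C(=O)OC(C)Cn1cnc2c1c(=O)n(C)c(=O)n2C)c1cccc2ccccc12`, which in this assay gives 87.7%; the step of a number 1.4 percentage points lower from compound 1 to compound 2 (within the scatter) is within the scatter. Furthest is compound 3 `CC(Cn1cnc2c1c(=O)n(C)c(=O)n2C)OCc1cn(CCCn2cnc3c(Br)c(Br)c(Br)c(Br)c32)nn1`, which in this assay gives 29.7%; no single-change step connects compound 3 to compound 2.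

Compound 4 `COC(C(=O)OC(C)Cn1cnc2c1c(=O)n(C)c(=O)n2C)c1ccc(C(C)(C)C)cc1` differs from compound 2 by 4-(tert-butyl)phenyl in place of naphthalen-2-yl on a saturated chain carbon bound to a carbonyl carbon and an oxygen on a saturated carbon. Within the data shown here, the only measured step, a number 1.4 percentage points lower from compound 1 to compound 2 (within the scatter), exchanged one group of two six-membered aromatic rings of carbon only for another and stayed within the scatter; no measured step replaces such a group with one six-membered aromatic ring of carbon only. So little change is expected, a number 2.3 percentage points lower from compound 2 to compound 4 (within the scatter), with a wide range. Compound 4 is estimated at 84%, between 62% and 96%.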

Compound 4, a percentage reported as activity, at one concentration (the size of the read-out at that concentration, not a potency): 79.5%
Estimate against measurement, compound 4: 4.5 percentage points above, and the stated range covers the measured number.
By their numbers in this assay, from the lowest: compound 3; then compounds 4, 2 and 1 (each within the scatter of the next).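

In this assay, a group with one six-membered aromatic ring of carbon only replaces one with two such rings, and the number of heavy atoms stays the same. 4-(tert-butyl)phenyl in place of naphthalen-2-yl gives a number 6.8 percentage points lower from compound 2 to compound 4 (within the scatter) and, in place of naphthalen-1-yl, a number 8.2 percentage points lower from compound 1 to compound 4 (within the scatter), so losing a ring at this position moves the read-out by no more than the usual scatter. Nothing available explains these small steps.

All three groups at this position are built of carbon only and have no hydrogen-bond donors or acceptors. On these data alone, what an amine or a carboxylic acid would do here remains open.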